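The compounds below may be only part of what the source reports. "The series", "measured", "known", "first", "only" and "open" are said of these compounds alone.

Of the compounds shown here, three have so far been measured in an ADME assay on L02 cells (Homo sapiens) for inhibition, read by MTT assay, with a stated time of 48 h, tested at 100 uM; a lower number here means less inhibition, a higher number more inhibition at the concentration tested (going by the name of the read-out). Compound 1, with the structure `Nc1ccc(-c2nsc(=O)o2)cc1`, gives 39.5%. Compound 2, with the structure `O=c1nc(-c2ccccc2Cl)ss1`, gives 40.1%, and compound 3, with the structure `Nc1ccc(-c2nc(=O)ss2)cc1`, gives 46.3%. Among these three numbers compound 1 stands lowest, yet its gaps to compound 2 and to compound 3 both lie within the usual scatter of repeated measurements, so the three results cannot be told apart with any confidence.

Compound 4, with the structure `O=c1oc(-c2ccc(F)cc2)ns1`, is the next compound to be measured in this assay. It differs from compound 1 in a single place: fluoro in place of amino on an aromatic carbon. Among the compounds with values here, no step between two measured compounds shows the effect of exactly this exchange, so there is no direct guide. What can be said is that compound 2, which carries no amino group on its six-membered aromatic ring of carbon only, and compound 1, which does, give numbers within the scatter of each other. On that basis the step of a number 1.5 percentage points higher from compound 1 to compound 4 (within the scatter) is expected to be small, with no clear direction and most likely not beyond the scatter. Compound 4 is therefore estimated at 41%, expected to fall between 28% and 55%.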

Compound 4, a percentage reported as inhibition, at one concentration (the size of the read-out at that concentration, not a potency): 21.7%
The estimate for compound 4 lay 19.3 percentage points above the measured number; the whole stated range lies above it.
By their numbers in this assay, from the lowest: compound 4; then compounds 1, 2 and 3 (each within the scatter of the next).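

In this assay, putting fluoro in place of amino on the aromatic carbon gives a number 17.8 percentage points lower from compound 1 to compound 4 (beyond the scatter), which shows that the group at this position can shift the reading by more than repeat measurements would. Within the data shown here, the three earlier numbers could not show this, as they lay within the scatter of one another and no two of those compounds differed in only one place, so this is the first single change that can be read directly. The exchange replaces a group counted with 1 hydrogen-bond donor and 1 hydrogen-bond acceptor by one counted with 0 of each, but nothing available explains why the number falls.

A single exchange cannot separate an effect of adding fluoro from an effect of losing amino, and a plain hydrogen, a hydroxyl or a methoxy at the same place would help tell these apart in this assay. On these data alone, it also remains open whether the same exchange would lower the number on the core of compound 3, which carries amino too.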